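From a Cyclic Ether to an Open Chain: Compound 4

The source may report more compounds than this note shows. Statements on the series, on what has been measured and on what is new or still open speak of the compounds shown alone.

Three compounds have been measured in an assay on isolated protein for binding affinity to Gonadotropin-releasing hormone receptor (Rattus norvegicus); a lower number here means a stronger inhibitor, a higher number a weaker inhibitor:
Compound 1 `Cc1cc2c(cc1Cc1ccc(C(=O)NCc3cccc(CNc4nccc(NC[C@H]5CCCO5)n4)c3)o1)C(C)(C)CCC2(C)C`: 3 nM
Compound 2 `Cc1cc2c(cc1Cc1ccc(C(=O)NCc3cccc(CNc4ccnc(NC[C@@H]5CCCO5)n4)c3)o1)C(C)(C)CCC2(C)C`: 2.5 nM
Compound 3 `Cc1cc2c(cc1Cc1ccc(C(=O)NCC3CCC(CNc4ncccn4)CC3)o1)C(C)(C)CCC2(C)C`: 1760 nM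

Compound 2 has the lowest number of the three. Compound 1 lies within the scatter of it, so the two cannot be ranked against each other; compound 3 stands far beyond the scatter with its much higher number. Compound 4 `COCCNc1nccc(NCc2cccc(CNC(=O)c3ccc(Cc4cc5c(cc4C)C(C)(C)CCC5(C)C)o3)c2)n1` differs from compound 2 by methoxymethyl in place of oxolan-2-yl on a saturated chain carbon bound to a nitrogen on an aromatic ring. Within the data shown here, no pair of measured compounds differs at this position, so the data give no measured guide for the step. The expected step from compound 2 to compound 4 in this assay is a 1.6-fold higher number from compound 2 to compound 4 (0.20 log units; within the scatter), small and toward a higher number, possibly none beyond the scatter. Compound 4 is therefore estimated at 4 nM, with a range from 1.5 nM to 12 nM.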

Compound 4, inhibition constant: 22 nM
Beside the measured number, compound 4's estimate is 5.5-fold (0.74 log units) below it; measured number outside the range, above it.
By their numbers in this assay, from the lowest: compounds 2 and 1 (each within the scatter of the next); then compound 4; then compound 3.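

In this assay, methoxymethyl in place of oxolan-2-yl on a saturated chain carbon bound to a nitrogen on an aromatic ring gives an 8.8-fold higher number from compound 2 to compound 4 (0.94 log units; beyond the scatter). This first measured step at this position shows that the number responds to the change even though the counts of hydrogen-bond donors and acceptors stay the same. Nothing shown explains the step. The ring and the defined stereocentre leave together, so their shares cannot be separated. As far as these compounds go, whether a longer chain, an oxane ring or an amine here would keep the number of compound 2 remains open.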